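Benzyl for 4-ethylphenyl on the amide nitrogen

The source may hold more compounds than are shown below. What is called first, only, known or untested is meant among the compounds shown, and "the series" means these compounds.

Compound 1 `CCc1ccc(NC(=O)C2CCN(C/C=C/c3ccccc3)CC2)cc1` is measured in a functional assay on MCF7 cells (Homo sapiens) for inhibition, read by MTT assay, with a stated time of 72 h (a lower number here means a stronger inhibitor, a higher number a weaker inhibitor), at 20000 nM. Among the three numbers in hand compound 1 stands second highest: compound 2 `O=C(Nc1cccc(Br)c1)C1CCN(C/C=C/c2ccccc2)CC1` gives 11500 nM in this assay, and compound 3 `N#Cc1ccc(NC(=O)C2CCN(C/C=C/c3ccccc3)CC2)cc1` gives 44500 nM. The step of a 1.7-fold lower number from compound 1 to compound 2 (0.24 log units; within the scatter) lies within the scatter, while a 2.2-fold higher number from compound 1 to compound 3 (0.35 log units; beyond the scatter) and a 3.9-fold higher number from compound 2 to compound 3 (0.59 log units; beyond the scatter) are modest. All three measured compounds share the core of compound 1 and differ only in the group on the amide-type nitrogen.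

Compound 4 `O=C(NCc1ccccc1)C1CCN(C/C=C/c2ccccc2)CC1` has not been measured. It differs from compound 1 by benzyl in place of 4-ethylphenyl on an amide-type nitrogen. Among the compounds with values here, none of the measured steps exchanges a substituted phenyl for benzyl on that nitrogen; each exchanges one substituted phenyl for another, and those exchanges moved the number by at most the modest 3.9-fold higher number from compound 2 to compound 3 (0.59 log units; beyond the scatter). The expected step is therefore small, estimated as a 1.3-fold higher number from compound 1 to compound 4 (0.10 log units; within the scatter), with no firm direction and possibly none beyond the scatter. For compound 4 the expected value in this assay is 25000 nM, with a range of 10000 nM to 60000 nM.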

Compound 4, half-maximal inhibitory concentration: > 100000 nM
Compound 4 ended at the assay's limit; the forecaster's own chance of this, stated with the estimate: 15%; middle value at least 4.0-fold (0.60 log units) from the limit.
By their numbers in this assay, from the lowest: compounds 2 and 1 (each within the scatter of the next); then compound 3. At a limit, above all of these: compound 4.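

Compound 4 stands at a limit of this assay, which is not a number: the limit of > 100000 nM in this assay, at which 1 of the 4 values shown sits. The exchange for benzyl on the amide-type nitrogen gives an at least 5.0-fold higher number from compound 1 to compound 4 (0.69 log units; beyond the scatter), an at least 2.2-fold higher number from compound 3 to compound 4 (0.35 log units; beyond the scatter) and an at least 8.6-fold higher number from compound 2 to compound 4 (0.93 log units; beyond the scatter), and the first and last of these exceed the largest step among the substituted phenyl groups, a 3.9-fold higher number from compound 2 to compound 3 (0.59 log units; beyond the scatter). Benzyl and 4-ethylphenyl each carry one six-membered aromatic ring of carbon only, so the presence of that ring on this nitrogen does not by itself keep the reading within the range of compounds 1, 2 and 3.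

From the compounds shown here alone, whether an unsubstituted phenyl or a 2-phenylethyl group on that nitrogen would return a number within that range stays open. Going by these compounds, how far compound 4 lies past its limit also stays open, so the three steps to it are lower bounds only.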